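Replacing the Bromophenyl Group: Expectation for Compound 4

This account rests on a few compounds, and the source may have more. Where it says the series, first, only, none or still open, it means among the compounds named here.

Three compounds have been measured in a functional assay on MGC-803 cells (Homo sapiens) for inhibition, read by MTT assay, with a stated time of 72 h; a lower number here means a stronger inhibitor, a higher number a weaker inhibitor:

Compound 1 `O=C(CSc1nc(Nc2ccccc2)c2ccccc2n1)Nc1cccc(Cl)c1` gives 14300 nM.
Compound 2 `O=C(CSc1nc(Nc2ccccc2)c2ccccc2n1)Nc1ccc(Cl)c(Cl)c1` gives 37900 nM.
Compound 3 `C=CC(=O)Nc1cccc(NC(=O)CSc2nc(Nc3ccccc3Br)c3ccccc3n2)c1` gives 12800 nM.

Compound 3 has the lowest of the three numbers. Compound 1 lies within the usual scatter of it, so the two cannot be ranked, while compound 2 stands beyond the scatter above both. Within the data shown here, the only step between compounds that differ in a single place is a 2.7-fold higher number from compound 1 to compound 2 (0.42 log units; beyond the scatter); that change sits on the ring carried by the amide, not on the nitrogen where compound 4 differs from compound 3.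

Compound 4 `C=CC(=O)Nc1cccc(NC(=O)CSc2nc(Nc3ccc(CC)cc3)c3ccccc3n2)c1` is related to compound 3 by one change: 4-ethylphenyl in place of 2-bromophenyl on a nitrogen on an aromatic ring. Among the measured compounds shown here, no measured pair isolates this change. Compounds 1 and 2 carry a plain phenyl on that nitrogen, but each also differs from compound 3 elsewhere, so their values say nothing direct about it. For the measured compounds named here, with no bearing step available, the expectation is that the number stays close to that of compound 3, and the estimated step of a 1.2-fold higher number from compound 3 to compound 4 (0.07 log units; within the scatter) is not expected to exceed the scatter. Compound 4 is therefore estimated at 15000 nM, within a range of 5000 nM to 50000 nM, and the measurement will show whether that holds.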

Compound 4, half-maximal inhibitory concentration: 8010 nM
For compound 4 the middle estimate is 1.9-fold (0.27 log units) above the measured one; the range from low to high includes it.
By their numbers in this assay, from the lowest: compounds 4, 3 and 1 (each within the scatter of the next); then compound 2.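

In this assay, among these compounds, moving to 4-ethylphenyl in place of 2-bromophenyl on the nitrogen gives a 1.6-fold lower number from compound 3 to compound 4 (0.20 log units; within the scatter), the first step that can be read at this position. The ring stays a six-membered carbon ring with no hydrogen-bond donors or acceptors, while the group goes from 7 heavy atoms, one of them bromine, to 8 carbons, and this exchange leaves the number within the usual scatter of repeated measurements. At this level of resolution the two substituted phenyl groups cannot be told apart, and no measurement is available that would explain the result.

The change replaces the bromine with an ethyl group and also alters where the substituent sits on the ring, and the compounds shown do not separate these two differences. Also open, from the compounds shown here alone, is whether the number would remain in this range with an amine, a carboxylic acid or a longer chain such as butyl on that phenyl ring, or with the ring replaced by a pyridine.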